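Methoxy to nitro on the aryl urea of compound 3

A few compounds are considered here, and "the series" means these few. Any claim that something is new, unique, unknown or untested is made for them only; others in the source may bear on it.

Measured so far:
compound 1 `O=C(Nc1ccccc1F)N1CCN(c2ccnc(Cl)n2)CC1` 787 nM
compound 2 `O=C(Nc1ccccc1C(F)(F)F)N1CCN(c2ccnc(Cl)n2)CC1` 136 nM
compound 3 `COc1ccccc1NC(=O)N1CCN(c2ccnc(Cl)n2)CC1` 9420 nM

In an assay on isolated protein for antagonist activity at transient receptor potential cation channel subfamily V member 1 (Homo sapiens) (on this read-out lower numbers stand for stronger inhibition and higher numbers for weaker inhibition), compound 3 stands highest of the three numbers; compound 1 is nearest and compound 2 furthest. The step to compound 4 `O=C(Nc1ccccc1[N+](=O)[O-])N1CCN(c2ccnc(Cl)n2)CC1` is nitro in place of methoxy on an aromatic carbon. Within the data shown here, two measured steps bear on it: a 12-fold higher number from compound 1 to compound 3 (1.08 log units; beyond the scatter) and a 69-fold higher number from compound 2 to compound 3 (1.84 log units; beyond the scatter). Both show that methoxy at this place gave far weaker inhibition than either fluoro or trifluoromethyl, so removing the methoxy is expected to lower the number, with the size uncertain since nitro was not measured anywhere. For compound 4 the expected step is a 13-fold lower number from compound 3 to compound 4 (1.13 log units; beyond the scatter). Compound 4 is therefore estimated at 700 nM, within 150 nM to 3500 nM.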

Compound 4, half-maximal inhibitory concentration: 854 nM
Compound 4: the middle estimate sits 1.2-fold (0.09 log units) below what was measured; measured number inside the range.
By their numbers in this assay, from the lowest: compound 2; then compounds 1 and 4 (each within the scatter of the next); then compound 3.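

In this assay, nitro in place of methoxy gives an 11-fold lower number from compound 3 to compound 4 (1.04 log units; beyond the scatter), so methoxy is not matched by this larger group with more hydrogen-bond acceptors. Nitro and fluoro cannot be told apart at this place, with a 1.1-fold higher number from compound 1 to compound 4 (0.04 log units; within the scatter), while trifluoromethyl keeps the lowest number of the four, with a 6.3-fold higher number from compound 2 to compound 4 (0.80 log units; beyond the scatter). Nothing available explains why methoxy stands apart from the other three groups.

On these data alone, whether an amine or a carboxylic acid at this place would fall near nitro or near methoxy stays open. So does whether these steps would hold on a different core.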